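Swapping the styryl arm for a methylphenyl ring

The source may report more compounds than this note shows. Statements on the series, on what has been measured and on what is new or still open speak of the compounds shown alone.

Measured compounds:
compound 1, `COC(=O)/C=C/c1cccc(N(Cc2ccc(/C=C/c3c(F)cccc3F)cc2)C(=O)C(C)C)c1`: 108 nM
compound 2, `COC(=O)/C=C/c1cccc(N(Cc2ccc(/C=C/c3ccccc3F)cc2)C(=O)C2CCCCC2)c1`: 64 nM
compound 3, `COC(=O)/C=C/c1cccc(N(Cc2ccc(-c3ccc(F)c(F)c3)cc2)C(=O)C2CCCCC2)c1`: 72 nM

These three compounds share a core and differ only in the group hanging from the outer aromatic ring. In an assay on isolated protein with Bile acid receptor (Homo sapiens) as the target (a lower number here means that less compound is needed, a higher number that more compound is needed for the effect), compound 1 gives 108 nM, the highest of the three numbers, yet both compound 3 with 72 nM and compound 2 with 64 nM sit within the scatter of it, so the three cannot be told apart.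

Compound 4, `COC(=O)/C=C/c1cccc(N(Cc2ccc(-c3cccc(C)c3)cc2)C(=O)C(C)C)c1`, has not been measured. It arises from compound 1 by the change (3-methylphenyl in place of 2-(2,6-difluorophenyl)ethenyl on an aromatic carbon), on an aromatic carbon, para to a large group.

Among the compounds with values here, the one measured step that bears on such a change is a 1.1-fold higher number from compound 2 to compound 3 (0.05 log units; within the scatter), where a fluorinated ethenyl linker was likewise replaced by a directly attached fluorinated ring. That step stayed within the scatter. Within the data shown here, no measured compound carries a methyl group, so nothing shows what the 3-methylphenyl group itself does. On that basis the step from compound 1 to compound 4 is expected to be small, about a 1.0-fold higher number from compound 1 to compound 4 (0.01 log units; within the scatter), with no clear direction.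

Compound 4 is therefore estimated at 110 nM in this assay, with a range from 40 nM to 300 nM.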

Compound 4, half-maximal effective concentration: 163 nM
For compound 4 the middle estimate is 1.5-fold (0.17 log units) below the measured one; the measured number falls inside the stated range.
By their numbers in this assay, from the lowest: compounds 2, 3, 1 and 4 (each within the scatter of the next, the first and the last beyond it).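

In this assay, the swap at this aromatic carbon, para to a large group, gives a 1.5-fold higher number from compound 1 to compound 4 (0.18 log units; within the scatter) even though it takes out the double bond of the ethenyl link and both fluorines and leaves a smaller group. The earlier swap of this kind, a 1.1-fold higher number from compound 2 to compound 3 (0.05 log units; within the scatter), still left fluorine on the incoming ring, so the new pair adds a case in which a directly attached ring without any fluorine stays within the scatter of the styryl-type arm it replaces. Together, these two pairs show that the number is not lost when this arm is shortened to a single ring, and nothing available explains why the change is tolerated.

Because the link and the fluorines leave together, the pair cannot separate their contributions, which 2-(3-methylphenyl)ethenyl or an unsubstituted phenyl ring in the same place could help to do. On these data alone, it also remains open how this assay would respond to a ring carrying an amine or a carboxylic acid in place of the methyl group.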